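A Second Methoxy Group on an Inactive Analogue

This account rests on a few compounds, and the source may have more. Where it says the series, first, only, none or still open, it means among the compounds named here.

Compound 1, `O=C1/C(=C/c2ccc(Cl)cc2Cl)c2ccccc2N1c1c(Cl)cccc1Cl`, was tested in a functional assay on SW-620 cells (Homo sapiens) for cytotoxicity, read by MTT assay, with a stated time of 3 days (a lower number here means that less compound is needed, a higher number that more compound is needed for the effect), where compound 1 gives 2 ug/mL. Compound 2, `COc1ccc(/C=C2/C(=O)N(c3c(Cl)cccc3Cl)c3ccccc32)cc1`, reaches only the limit of this assay, so compound 2 gives > 100 ug/mL. For the measured compounds named here, the single measured step, an at least 50-fold higher number from compound 1 to compound 2 (1.69 log units; beyond the scatter), rests on (the limit of > 100 ug/mL in this assay, at which 1 of the 2 values shown sits). Compound 3, `COc1ccc(/C=C2/C(=O)N(c3c(Cl)cccc3Cl)c3ccccc32)cc1OC`, differs from compound 2 by methoxy in place of hydrogen on an aromatic carbon. Going by the values given here, no measured step covers this change, so no shift beyond the scatter is expected, and the limit may again be reached. Compound 3 is therefore estimated at 100 ug/mL, between 30 ug/mL and 300 ug/mL, an expected step of a number no higher from compound 2 to compound 3 (the limit leaves the size open).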

Compound 3, concentration for half-maximal effect: 50 ug/mL
The estimate for compound 3 lay 2.0-fold (0.30 log units) above the measured number; the measured number falls inside the stated range.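

With methoxy in place of hydrogen, ortho to a methoxy group, compound 3 gives a true number in this assay, 50 ug/mL. The change reads as an at least 2.0-fold lower number from compound 2 to compound 3 (0.30 log units; that floor lies within the scatter), so it cannot be told apart from no shift at all, though the real step may be larger. Its size stays open, since compound 2 stands at a limit of the assay and not at a number: the limit of > 100 ug/mL in this assay, at which 1 of the 3 values shown sits.

From the compounds shown here alone, what a hydroxyl group or an amine would do at this position remains open, as does the effect of a longer alkoxy chain there.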